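Open Chain Amine in Place of a Cyclic Amine

This account rests on a few compounds, and the source may have more. Where it says the series, first, only, none or still open, it means among the compounds named here.

Compound 1 `c1ccc(Nc2nccc(-c3ccncc3)n2)cc1` gives 900 nM in a functional assay for inhibition, with Homo sapiens as the target; a higher number here means a weaker inhibitor, a lower number a stronger inhibitor.
Compound 2 `CC1CCN(c2ccc(Nc3nccc(-c4ccncc4)n3)cc2)CC1` gives 600 nM in this assay.

For the measured compounds named here, compound 2 shows the lowest of the two numbers, though the gap to its one neighbour lies within the scatter: a 1.5-fold lower number from compound 1 to compound 2 (0.18 log units; within the scatter). Compound 3 `CCN(CC)CCCOc1ccc(Nc2nccc(-c3ccncc3)n2)cc1` carries 3-(diethylamino)propoxy in place of 4-methylpiperidin-1-yl on an aromatic carbon. Going by the values given here, only that single step, from hydrogen to 4-methylpiperidin-1-yl, touches this position, and it did not move the number beyond the scatter; no measured pair tells how 3-(diethylamino)propoxy behaves there. Compound 3 is therefore expected to move little, a 1.2-fold lower number from compound 2 to compound 3 (0.08 log units; within the scatter). The estimate for compound 3 is 500 nM, within 150 nM to 1700 nM.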

Compound 3, half-maximal inhibitory concentration: 1300 nM
For compound 3 the middle estimate is 2.6-fold (0.41 log units) below the measured one; low and high end bracket the measured number.
By their numbers in this assay, from the lowest: compounds 2, 1 and 3 (each within the scatter of the next, the first and the last beyond it).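

For the compounds shown here, replacing 4-methylpiperidin-1-yl with the ring-free 3-(diethylamino)propoxy chain gives the first step at this position that lies beyond the scatter, though a modest one: a 2.2-fold higher number from compound 2 to compound 3 (0.34 log units; beyond the scatter). Measured against hydrogen, the same chain stays within the scatter, a 1.4-fold higher number from compound 1 to compound 3 (0.16 log units; within the scatter), so neither large group clearly separates from hydrogen here. Nothing in the available evidence accounts for the shift.

The change swaps the ring and the linking oxygen together, and these compounds cannot tell the two apart. A 3-(piperidin-1-yl)propoxy group, which joins the ring to the oxygen-linked chain, would help separate them.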